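The compounds below may be only part of what the source reports. "The series", "measured", "known", "first", "only" and "open" are said of these compounds alone.

Measured so far in an ADME assay on HEK293 cells (Homo sapiens) for inhibition, with a stated time of 72 h; on this read-out higher numbers stand for an effect only at larger amounts of compound and lower numbers for an effect already at smaller amounts:
- compound 1 `C/C=C/C(=O)Nc1cccc(-c2nc3ccccc3s2)c1` gives > 25000 nM, which is a limit of the assay.
- compound 2 `C=C(C)C(=O)Nc1cccc(-c2nc3ccccc3s2)c1` gives > 25000 nM, which is a limit of the assay.
- compound 3 `CC(Cl)C(=O)Nc1cccc(-c2nc3ccccc3s2)c1` gives > 25000 nM, which is a limit of the assay.

Compound 3 therefore stands only at a limit in this assay, and the two other values shown are limits as well. The steps that touch it, a step that the two limits leave unreadable from compound 1 to compound 3 and a step that the two limits leave unreadable from compound 2 to compound 3, cannot be read in size, and the same holds for a step that the two limits leave unreadable from compound 1 to compound 2. The shared picture is the limit of > 25000 nM in this assay, at which 3 of the 3 values shown sit.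

Compound 4 `O=C(Nc1cccc(-c2nc3ccccc3s2)c1)c1cnccc1Cl` differs from compound 3 by 4-chloropyridin-3-yl in place of 1-chloroethyl on a carbonyl carbon. Within the data shown here, no measured step bears readably on this change, since every step runs between two limits. With three limits and no readable step, the expectation for compound 4 in this assay is that the step that the limit leaves unreadable from compound 3 to compound 4 stays unreadable, and that compound 4 will most likely again be reported at the limit. The estimate for compound 4 is 30000 nM, within 5000 nM to 150000 nM.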

Compound 4, half-maximal effective concentration: > 25000 nM
Compound 4 ended at the assay's limit (the forecaster's own chance of this, stated with the estimate: 80%); the middle value does not contradict the limit.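

No step among compound 1, compound 2, compound 3 and compound 4 can be read in this assay, since each comparison runs between two limits: the limit of > 25000 nM in this assay, at which 4 of the 4 values shown sit.

The compounds shown leave open how far each lies beyond that limit, and whether any group on the carbonyl carbon changes the read-out.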